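This account rests on a few compounds, and the source may have more. Where it says the series, first, only, none or still open, it means among the compounds named here.

Compound 1 `Cc1cn([C@@H]2C[C@H](O)[C@@H](CNC(=O)Nc3ccc(C(C)(C)C)cc3)O2)c(=O)[nH]c1=O` — in an ADME assay on MRC5 cells (Homo sapiens) for cytotoxicity (a higher number here means that more compound is tolerated, a lower number that less compound is tolerated), compound 1 gives > 50000 nM, which is a limit of the assay and not a number.
Compound 2 `Cc1cn([C@@H]2C[C@H](O)[C@@H](CNC(=S)Nc3ccc(Cl)c(C(F)(F)F)c3)O2)c(=O)[nH]c1=O` — in this assay compound 2 gives > 50000 nM, again a limit.
Compound 3 `Cc1cn([C@@H]2C[C@H](O)[C@@H](CNC(=O)Nc3ccccc3COc3ccccc3)O2)c(=O)[nH]c1=O` — in this assay compound 3 gives > 50000 nM, again a limit.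

Compound 1 therefore stands where all three values stand, at the limit of > 50000 nM in this assay, at which 3 of the 3 values shown sit. No measured step between any two of these compounds exists, and the three values show only that none of them reached a measurable cytotoxic concentration.

Compound 4 `Cc1cn([C@@H]2C[C@H](O)[C@@H](CNC(=O)Nc3ccc(Cc4ccccc4)cc3)O2)c(=O)[nH]c1=O` differs from compound 1 by benzyl in place of tert-butyl on an aromatic carbon. With every value shown sitting at the limit, the step that the limit leaves unreadable from compound 1 to compound 4 is expected to be none beyond the scatter. Compound 4 is estimated at 60000 nM, between 20000 nM and 150000 nM, and is expected most likely to return a limit once more.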

Compound 4, half-maximal cytotoxic concentration: > 50000 nM
Compound 4: no number, only a limit; the forecaster's own chance of this, stated with the estimate: 80%; the middle value lies beyond the limit too.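

Within the data shown here, compound 1 and compound 4 both return limits and not numbers in this assay, so no step between them can be read. The compounds shown leave open at what concentration any of them becomes cytotoxic to these cells.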